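The compounds below may be only part of what the source reports. "The series", "measured", "known", "first", "only" and "open" are said of these compounds alone.

Working notes on the series, read in an ADME assay on the whole organism (plasma, strain Sprague-Dawley) for pharmacokinetics, with Rattus norvegicus as the target; a lower number here means slower removal, a higher number faster removal of the compound. Compound 1 (`Nc1nc2c(s1)CCC[C@H]2C(=O)Nc1ccc(C[C@@H]2CC[C@H]([C@H](O)c3ccccc3)N2)cc1`) gives 185 mL/min/kg, compound 2 (`Nc1nc2c(s1)CC[C@H]2C(=O)Nc1ccc(C[C@@H]2CC[C@H]([C@H](O)c3cccnc3)N2)cc1`) gives 32 mL/min/kg and compound 3 (`Cc1nc2c(s1)CC[C@H]2C(=O)Nc1ccc(C[C@@H]2CC[C@H]([C@H](O)c3ccccc3)N2)cc1`) gives 87 mL/min/kg. Compound 3 thus holds the second highest of the three numbers, below compound 1 and above compound 2.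

Compound 4 (`Cc1nc2c(s1)CC[C@H]2C(=O)Nc1ccc(C[C@@H]2CC[C@H]([C@H](O)c3cccnc3)N2)cc1`) has pyridin-3-yl in place of phenyl on a saturated chain carbon bound to an oxygen on a saturated carbon and a saturated ring carbon.

Among the measured compounds shown here, the only measured step is a 2.1-fold lower number from compound 1 to compound 3 (0.33 log units; beyond the scatter). For the measured compounds named here, it concerns the group on a carbonyl carbon, not this change, so no measured pair isolates the new swap. The closest evidence is compound 2, which carries pyridin-3-yl and gives 32 mL/min/kg, although it also differs from compound 3 in another place.

A move to a lower number in this assay is therefore expected, with an estimated size of a 2.2-fold lower number from compound 3 to compound 4 (0.34 log units; beyond the scatter). For compound 4 the estimated value is 40 mL/min/kg, with an expected range of 18 mL/min/kg to 80 mL/min/kg.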

Compound 4, clearance: 25 mL/min/kg
Compound 4: middle estimate off by 1.6-fold (0.20 log units), on the high side, within the range that was stated.
By their numbers in this assay, from the lowest: compounds 4 and 2 (each within the scatter of the next); then compound 3; then compound 1.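

In this assay the swap to pyridin-3-yl on a saturated chain carbon bound to an oxygen on a saturated carbon and a saturated ring carbon can now be read on its own, and it gives a 3.5-fold lower number from compound 3 to compound 4 (0.54 log units; beyond the scatter) with nothing else changed. With pyridin-3-yl held in place, methyl in place of amino on an aromatic carbon gives a 1.3-fold lower number from compound 2 to compound 4 (0.11 log units; within the scatter), so the two groups are not told apart here and the swap on the chain carbon is the step that shows a change. No measurement at hand accounts for the step.

The compounds shown leave open whether a pyrimidine ring at this place would lower the number further. They also leave open whether pyridin-3-yl gives a step of similar size on the carbonyl-carbon group of compound 1.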